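The source may report more compounds than this note shows. Statements on the series, on what has been measured and on what is new or still open speak of the compounds shown alone.

Measured so far:
Compound 1, `O=[N+]([O-])c1ccccc1OC(CCn1ccnc1)c1ccccc1`: 18 ug/mL
Compound 2, `CC(CCn1ccnc1)Oc1ccccc1[N+](=O)[O-]`: > 100 ug/mL

Both were tested in an ADME assay on J774.A1 cells (Mus musculus) for cytotoxicity, read by MTT assay; on this read-out higher numbers stand for lower toxicity in this test and lower numbers for higher toxicity in this test. Compound 1 gives 18 ug/mL. For compound 2 the reading is > 100 ug/mL, which is a limit of the assay and not a number. Compound 2 thus sits at the limit of > 100 ug/mL in this assay, at which 1 of the 2 values shown sits, so it stands at the less toxic end of what was measured, without an exact value.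

Compound 3, `O=[N+]([O-])c1ccccc1OC(CCn1ccnc1)COc1ccccc1`, differs from compound 2 by phenoxy in place of hydrogen on a saturated chain carbon, two bonds along the chain from an oxygen on an aromatic ring. Among the measured compounds shown here, the only measured step that bears on this is an at least 5.5-fold higher number from compound 1 to compound 2 (0.74 log units; beyond the scatter), in which the compound carrying an aromatic ring on the chain, compound 1, gave the lower number. Compound 3 again carries an aromatic ring on the chain, although as phenoxy rather than phenyl and at a different chain carbon, so the step is read in the reverse direction. Compound 3 is therefore expected to show a lower number than compound 2, by an at least 2.5-fold lower number from compound 2 to compound 3 (0.39 log units; beyond the scatter). The value for compound 3 in this assay is estimated at 40 ug/mL, within a range from 12 ug/mL to 120 ug/mL.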

Compound 3, half-maximal cytotoxic concentration: 36.2 ug/mL
For compound 3 the middle estimate is 1.1-fold (0.04 log units) above the measured one, and the stated range covers the measured number.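

In this assay, the lower number that came with a phenyl on this chain carbon is not unique to phenyl: moving from methyl to phenoxymethyl, which is phenoxy in place of hydrogen, gives an at least 2.7-fold lower number from compound 2 to compound 3 (0.44 log units; beyond the scatter). The two ring-bearing groups cannot be told apart here, since the comparison between them gives a 2.0-fold higher number from compound 1 to compound 3 (0.30 log units; within the scatter), so compound 1 and compound 3 count as equally toxic in this test, and both stand apart from compound 2. The true size of that separation stays unknown, as the reading for compound 2 is a limit of the assay and not a number: the limit of > 100 ug/mL in this assay, at which 1 of the 3 values shown sits.

These three compounds cannot show whether the aromatic ring itself matters or whether any larger group at this carbon would do the same, and a saturated ring such as cyclohexyl or a plain longer chain such as butyl would separate those two readings. Going by these compounds, it also stays open how a carboxylic acid or an amine on the added phenoxy ring would move the number, and nothing here explains why the number falls.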